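A few compounds are considered here, and "the series" means these few. Any claim that something is new, unique, unknown or untested is made for them only; others in the source may bear on it.

Two compounds from one series have so far been run in an ADME assay on the whole organism (Rattus norvegicus), at a dose of 2 mg/kg by the oral route; on this read-out lower numbers stand for lower exposure and higher numbers for higher exposure at the dose given. Compound 1 `COc1cc(OCc2csc(-c3ccc(C(C)(C)O)cc3)n2)c2cc(-c3cn4nc(OC)sc4n3)oc2c1` gives 505 ng.h/mL in this assay, while compound 2 `COc1cc(OCc2cccc(-c3cnc(OC)cn3)c2)c2cc(-c3cn4nc(OC)sc4n3)oc2c1` gives 722 ng.h/mL; the gap between these two numbers is within the usual scatter of repeated measurements, so nothing separates them with confidence. Within the data shown here, no pair that differs in only one place has yet been measured, so no single step has been characterised.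

Compound 3 `COc1cc(OCc2csc(-c3ccccc3)n2)c2cc(-c3cn4nc(OC)sc4n3)oc2c1` is the next to be measured, and it differs from compound 1 in one place: hydrogen in place of 1-hydroxy-1-methylethyl on an aromatic carbon. This change removes the 1-hydroxy-1-methylethyl group from the aromatic carbon where it sits and leaves a hydrogen in its place, so that the 4-(1-hydroxy-1-methylethyl)phenyl becomes a plain phenyl.

Among the measured compounds shown here, with no comparable step among the measured compounds, only a cautious expectation is possible. The step from compound 1 to compound 3 is expected to be a 1.1-fold lower number from compound 1 to compound 3 (0.05 log units; within the scatter), that is, no change beyond the scatter in either direction. Compound 3 is accordingly expected to give about 450 ng.h/mL, within a range of 150 ng.h/mL to 1300 ng.h/mL.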

Compound 3, area under the concentration-time curve: 3920 ng.h/mL
Beside the measured number, compound 3's estimate is 8.7-fold (0.94 log units) below it; the whole stated range lies below it.
By their numbers in this assay, from the lowest: compounds 1 and 2 (each within the scatter of the next); then compound 3.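

Among these compounds, the step is the first that differs in one place, and it shows that this aromatic carbon, on the ring that is 4-(1-hydroxy-1-methylethyl)phenyl in compound 1 and plain phenyl in compound 3, matters in this assay: replacing the 1-hydroxy-1-methylethyl group with hydrogen gives a 7.8-fold higher number from compound 1 to compound 3 (0.89 log units; beyond the scatter). Oral exposure in the rat therefore responds to this single change, with the rest of the molecule held constant, and the plain phenyl stands on the higher side of the pair, although this rests on one pair alone. Nothing measured on these compounds indicates what lies behind the rise.

The compounds shown leave open whether the step belongs to the hydroxyl of the group or to its carbon frame, which a tert-butyl or a methyl at the same carbon would help to separate. They also leave open how a methoxy, an amine or a carboxylic acid at this carbon would compare, and whether the same change would act alike on other parts of the series, such as the shape of compound 2.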